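Swapping the side group on a sodium/hydrogen exchanger inhibitor

The source may hold more compounds than are shown below. What is called first, only, known or untested is meant among the compounds shown, and "the series" means these compounds.

Measured compounds:
compound 1 `CCCCCc1cc(C)c(C(=O)N=C(N)N)cc1S(C)(=O)=O`: 27 nM
compound 2 `Cc1cc(-c2ccccc2)c(S(C)(=O)=O)cc1C(=O)N=C(N)N`: 19 nM
compound 3 `Cc1cn(-c2cc(C)c(C(=O)N=C(N)N)cc2S(C)(=O)=O)cn1`: 28 nM

In a functional assay for inhibition of sodium/hydrogen exchanger (Oryctolagus cuniculus) (on this read-out higher numbers stand for weaker inhibition and lower numbers for stronger inhibition), compound 3 gives 28 nM. Its number sits alongside those of the other two: a 1.0-fold higher number from compound 1 to compound 3 (0.02 log units; within the scatter) and a 1.5-fold higher number from compound 2 to compound 3 (0.17 log units; within the scatter), both inside the usual scatter. Compound 4 `Cc1cc(Nc2cccc(Cl)c2)c(S(C)(=O)=O)cc1C(=O)N=C(N)N` has not been measured. It differs from compound 3 in one place: (3-chlorophenyl)amino in place of 4-methyl-1H-imidazol-1-yl on an aromatic carbon. The steps already seen at this same position bear on the change. Replacing pentyl by phenyl gave a 1.4-fold lower number from compound 1 to compound 2 (0.15 log units; within the scatter), and replacing phenyl by the 4-methyl-1H-imidazol-1-yl group gave a 1.5-fold higher number from compound 2 to compound 3 (0.17 log units; within the scatter). Three quite different groups at this carbon have therefore left this assay unchanged beyond the scatter. For the measured compounds named here, no measured compound carries an arylamino group here, so the expectation rests on that pattern alone. Compound 4 is expected to show a 1.1-fold lower number from compound 3 to compound 4 (0.05 log units; within the scatter), a step without direction beyond the scatter. The estimate for compound 4 is 25 nM, within a range from 8 nM to 80 nM.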

Compound 4, half-maximal inhibitory concentration: 33 nM
Compound 4: middle estimate off by 1.3-fold (0.12 log units), on the low side; measured number inside the range.
By their numbers in this assay, from the lowest: compounds 2, 1, 3 and 4 (each within the scatter of the next).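

In this assay, the (3-chlorophenyl)amino group of compound 4 fits with the earlier groups, with no step beyond the scatter: a 1.2-fold higher number from compound 3 to compound 4 (0.07 log units; within the scatter), a 1.7-fold higher number from compound 2 to compound 4 (0.24 log units; within the scatter) and a 1.2-fold higher number from compound 1 to compound 4 (0.09 log units; within the scatter). This is the first group shown here that carries a hydrogen-bond donor and a chlorine and reaches its ring through a nitrogen with a hydrogen, yet the four compounds remain within the scatter of one another, with none going against this pattern at the aromatic carbon ortho to a methylsulfonyl group. Nothing available explains why the number stays so flat across these groups.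

From the compounds shown here alone, whether a carboxylic acid, a dimethylamino group or a bare hydrogen at this carbon would give a similar number remains open. So does what phenylamino without the chlorine would give.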